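The compounds below may be only part of what the source reports. "The series", "measured", "known", "first", "only" and "open" are said of these compounds alone.

In a functional assay on cells (Melanoma cell, Homo sapiens) for inhibition (on this read-out lower numbers stand for stronger inhibition of growth and higher numbers for weaker inhibition of growth), compound 1 `Cc1cn2c(/C=N/Nc3ccccn3)c(-c3ccc(Cl)c([N+](=O)[O-])c3)nc2s1` gives 18200 nM, compound 2 `Cc1cn2c(/C=N/NC(=N)N)c(-c3ccsc3)nc2s1` gives 8130 nM and compound 3 `N=C(N)N/N=C/c1c(-c2ccsc2)nc2sccn12` gives 17000 nM. Compound 3 thus lies within the scatter of compound 1, while its number is higher than that of compound 2. Compound 4 `N=C(N)N/N=C/c1c(-c2cccs2)nc2sccn12` has not yet been measured. It differs from compound 3 by a single swap, thiophen-2-yl in place of thiophen-3-yl on an aromatic carbon. Among the compounds with values here, no measured step tests this swap directly. Within the data shown here, the one step available is a 2.1-fold higher number from compound 2 to compound 3 (0.32 log units; beyond the scatter), which comes from a different change, hydrogen in place of methyl on an aromatic carbon. It shows only that a small edit in this series can move the number modestly, and it gives no direction for the thiophene swap. The two groups also have the same counts of atoms, so no shift beyond the scatter is expected in this assay, and the estimated step is a 1.1-fold lower number from compound 3 to compound 4 (0.05 log units; within the scatter). For compound 4 the estimate is 15000 nM, with an expected range from 7000 nM to 32000 nM.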

Compound 4, concentration for 50% growth inhibition: 15100 nM
Beside the measured number, compound 4's estimate is 1.0-fold (0.00 log units) below it; low and high end bracket the measured number.
By their numbers in this assay, from the lowest: compounds 2, 4, 3 and 1 (each within the scatter of the next, the first and the last beyond it).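

Compound 3 and compound 4 carry the same thiophene ring on an aromatic carbon of the shared core, joined through a different ring atom. In this assay, thiophen-2-yl in place of thiophen-3-yl gives a 1.1-fold lower number from compound 3 to compound 4 (0.05 log units; within the scatter), so the two compounds cannot be told apart on this read-out. Within the data shown here, the earlier step concerned a methyl group elsewhere on the core, so this is the first direct test at this position, and it shows that the point of attachment of this ring makes no measurable difference here; nothing available explains this result.

The compounds shown leave open whether a plain phenyl ring or a furan-2-yl group at this position would give a similar number. They also leave open whether adding methyl to the core of compound 4 would have the same effect as the methyl that separates compound 2 from compound 3.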